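Methyl for chloro on the 2-chlorophenyl of compound 1

The source may hold more compounds than are shown below. What is called first, only, known or untested is meant among the compounds shown, and "the series" means these compounds.

Measured compounds:
compound 1, `CCCc1nc(-c2ccccc2)c(CNCCN2CCN(c3ccccc3Cl)CC2)o1`, 4370 nM
compound 2, `CCCc1nc(-c2ccccc2)c(CNCCCN2CCN(c3ccccc3Cl)CC2)o1`, 2800 nM
compound 3, `CCCc1nc(-c2ccccc2)c(CNCCN2CCN(C(c3ccccc3)c3ccccc3)CC2)o1`, 7470 nM

In an assay on HEK293 cells for inhibition of Voltage-dependent T-type calcium channel subunit alpha-1G (Homo sapiens), read by patch clamp (on this read-out lower numbers stand for stronger inhibition and higher numbers for weaker inhibition), compound 1 gives 4370 nM, the second highest of the three numbers. Compound 2 gives 2800 nM and compound 3 gives 7470 nM; both gaps to compound 1 are within the usual scatter, so the three numbers do not separate from one another.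

Compound 4, `CCCc1nc(-c2ccccc2)c(CNCCN2CCN(c3ccccc3C)CC2)o1`, differs from compound 1 in one place: methyl in place of chloro on an aromatic carbon. Going by the values given here, no measured pair in this set shows the same exchange, so no step size for it is known from these data, and nothing points one way or the other.

On that basis the step from compound 1 to compound 4 is expected to stay within the scatter, a 1.0-fold higher number from compound 1 to compound 4 (0.01 log units; within the scatter). Compound 4 is estimated at 4500 nM in this assay, with a range from 2000 nM to 10000 nM.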

Compound 4, half-maximal inhibitory concentration: 4300 nM
The estimate for compound 4 lay 1.0-fold (0.02 log units) above the measured number; the measured number falls inside the stated range.
By their numbers in this assay, from the lowest: compounds 2, 4, 1 and 3 (each within the scatter of the next, the first and the last beyond it).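

Going from 2-chlorophenyl to 2-methylphenyl in this assay gives a 1.0-fold lower number from compound 1 to compound 4 (0.01 log units; within the scatter), the only step among the compounds shown that differs in one place. At this position, ortho to a large group, chlorine is therefore not needed to keep the number of compound 1: a methyl serves equally well in this pair, though one exchange says nothing about other groups. No measurement at hand accounts for this result.

Open, as far as these compounds go, is whether a methoxy, a nitrile, an amine or plain hydrogen at this position would move this assay beyond the scatter from compound 1. Also open, from the compounds shown here alone, is whether the exchange of chloro for methyl would give a similar step on the scaffold of compound 2.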